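A few compounds are considered here, and "the series" means these few. Any claim that something is new, unique, unknown or untested is made for them only; others in the source may bear on it.

Working notes on a small series measured in a functional assay on MCF7 cells (Homo sapiens) for inhibition; a lower number here means a stronger inhibitor, a higher number a weaker inhibitor.

Compound 1 `CC(C)C(NC(=O)NO)C(=O)NC1CCCCC1` carries an isopropyl group on the chain. In this assay compound 1 gives only a limit, > 100000 nM. Compound 2 `CCC(C)C(NC(=O)NO)C(=O)NC1CCCCC1` carries a sec-butyl group at the same place. In this assay compound 2 likewise gives only a limit, > 100000 nM. The change from compound 2 to compound 1 is hydrogen in place of methyl on a saturated chain carbon, three bonds along the chain from an amide-type nitrogen and a carbonyl carbon, and the step it made, a step that the two limits leave unreadable from compound 2 to compound 1, cannot be read in size, because of the limit of > 100000 nM in this assay, at which 2 of the 3 values shown sit.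

Compound 3 `CCC(C)C1NC(=O)N(C2CCCC2)C1=O` is built on a different core, and the difference between the two cores is not broken down here. In this assay, going by the values given here, compound 3 gives 67400 nM, the only number in the set.

Compound 4 `CC(C)C1NC(=O)N(C2CCCC2)C1=O` is the not yet measured partner of compound 3. The change from compound 3 to compound 4 is hydrogen in place of methyl on a saturated chain carbon, two bonds along the chain from a saturated ring carbon. Among the compounds with values here, it is the same kind of change as the one from compound 2 to compound 1, methyl leaving and hydrogen entering on a saturated chain carbon, but the place is described differently: two bonds along the chain from a saturated ring carbon in compound 3, three bonds along the chain from an amide-type nitrogen and a carbonyl carbon in compound 2.

The earlier occurrence of this change gives no readable size, so the step expected from compound 3 to compound 4, a 1.1-fold higher number from compound 3 to compound 4 (0.05 log units; within the scatter), is taken as small and is an estimate only. Compound 4 is accordingly expected to give about 75000 nM in this assay, with a plausible range from 30000 nM to 200000 nM.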

Compound 4, half-maximal inhibitory concentration: > 100000 nM
Compound 4 gave a limit, no number; the forecaster's own chance of this, stated with the estimate: 35%; middle value at least 1.3-fold (0.12 log units) from the limit.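

In this assay, the change from sec-butyl to isopropyl on the core of compound 3 reads as an at least 1.4-fold higher number from compound 3 to compound 4 (0.17 log units; that floor lies within the scatter). Compound 4 gives only a limit, > 100000 nM, so the step is known only as a floor and its true size may be small or large. The same change on the core of compound 2 cannot be read, so the data neither show that the change carries from one core to the other nor show that it fails to, because only one end of one pair has a number: the limit of > 100000 nM in this assay, at which 3 of the 4 values shown sit.

Going by these compounds alone, still open is whether the change from sec-butyl to isopropyl has a measurable size on either core, since no pair has a number at both ends. Also open, on these data alone, is how a longer chain, such as n-hexyl, or a chain ending in an amine or a carboxylic acid would read in this assay in place of the sec-butyl group on either core.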